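Methyl in place of chloro: notes toward compound 3

A few compounds are considered here, and "the series" means these few. Any claim that something is new, unique, unknown or untested is made for them only; others in the source may bear on it.

Values in a functional assay on cells (T-cell line, Homo sapiens) for inhibition; on this read-out lower numbers stand for stronger inhibition and higher numbers for weaker inhibition:
- compound 1 `CN1CCC(COC(c2ccccc2)c2ccccc2)CC1`: > 20000 nM (a limit)
- compound 2 `Clc1ccc(CCCN2CCC(COC(c3ccccc3)c3ccccc3)CC2)cc1`: 500 nM

Among the measured compounds shown here, compound 2 at 500 nM holds the only true number so far. Compound 3 `Cc1ccc(CCCN2CCC(COC(c3ccccc3)c3ccccc3)CC2)cc1` is next, with methyl in place of chloro on an aromatic carbon. For the measured compounds named here, the sole measured step, an at least 40-fold lower number from compound 1 to compound 2 (1.60 log units; beyond the scatter), is large, but it adds the whole 2-(4-chlorophenyl)ethyl group and does not compare chloro with methyl. Going by the values given here, with that step as the only guide, no change beyond the scatter is expected in this assay, and no direction is favoured. The expected step is a 1.2-fold higher number from compound 2 to compound 3 (0.08 log units; within the scatter). For compound 3 the estimate is 600 nM, with an expected range of 200 nM to 1800 nM.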

Compound 3, half-maximal inhibitory concentration: 200 nM
Beside the measured number, compound 3's estimate is 3.0-fold (0.48 log units) above it; the measured number falls inside the stated range.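

In this assay, among the compounds shown here, the aromatic carbon para to a large group is sensitive to what sits on it, which the earlier compounds could not show: methyl in place of chloro gives a 2.5-fold lower number from compound 2 to compound 3 (0.40 log units; beyond the scatter) and so moves the number beyond the scatter. The 2-(4-methylphenyl)ethyl group gives an at least 100-fold lower number from compound 1 to compound 3 (2.00 log units; beyond the scatter) and this step is only a bound. Compound 1 stands at a limit: the limit of > 20000 nM in this assay, at which 1 of the 3 values shown sits.

On these data alone, whether methoxy, an amine or a carboxylic acid at this carbon would lower the number further stays open. So does the effect of a longer chain on the ring nitrogen.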